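Alkyl chain length in a diaryl urea series

The source may hold more compounds than are shown below. What is called first, only, known or untested is meant among the compounds shown, and "the series" means these compounds.

Compound 1 `CCCCCCCCCCCCCc1ccc(NC(=O)Nc2c(C(C)C)cccc2C(C)C)cc1`: 11 nM
Compound 2 `CCCCCCCCc1ccc(NC(=O)Nc2c(C(C)C)cccc2C(C)C)cc1`: 11 nM
Compound 3 `CCCCc1ccc(NC(=O)Nc2c(C(C)C)cccc2C(C)C)cc1`: 29 nM

In an assay on isolated protein for inhibition of acyl-CoA:cholesterol acyltransferase (Oryctolagus cuniculus) (on this read-out higher numbers stand for weaker inhibition and lower numbers for stronger inhibition), compound 3 gives the highest number of the three measured compounds, beyond the scatter against compound 1 and compound 2. Compound 4 `CCCCCCCCCCc1ccc(NC(=O)Nc2c(C(C)C)cccc2C(C)C)cc1` differs from compound 3 by hexyl in place of hydrogen on a saturated chain carbon, four bonds along the chain from an aromatic carbon. Among the measured compounds shown here, the steps that bear on this are a 2.6-fold higher number from compound 2 to compound 3 (0.42 log units; beyond the scatter) and a 2.6-fold higher number from compound 1 to compound 3 (0.42 log units; beyond the scatter), while no change at the digits printed from compound 1 to compound 2 (within the scatter) shows that once the chain is long the number stays flat. Lengthening the chain of compound 3 is therefore expected to give a modest lower number in this assay, of the order seen in those two steps, and an expected step of a 2.6-fold lower number from compound 3 to compound 4 (0.42 log units; beyond the scatter). Compound 4 is estimated at 11 nM, with a range of 6 nM to 22 nM.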

Compound 4, half-maximal inhibitory concentration: 13 nM
Estimate against measurement, compound 4: 1.2-fold (0.07 log units) below, and the stated range covers the measured number.
By their numbers in this assay, from the lowest: compounds 1, 2 and 4 (each within the scatter of the next); then compound 3.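

In this assay, hexyl in place of hydrogen on this saturated chain carbon gives a 2.2-fold lower number from compound 3 to compound 4 (0.35 log units; beyond the scatter) and brings compound 4 level with the other long-chain compounds. The comparisons with those compounds, a 1.2-fold higher number from compound 2 to compound 4 (0.07 log units; within the scatter) and a 1.2-fold higher number from compound 1 to compound 4 (0.07 log units; within the scatter), place a further point on the flat stretch, which now holds across three chain lengths.

Where between compound 3 and compound 2 the number stops falling remains open. So does whether a carboxylic acid or an amine at the far end of the chain would keep the number, and no measurement here accounts for the flat stretch.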